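From 2-chlorophenyl to 4-chlorophenyl, starting from a limit

The compounds below may be only part of what the source reports. "The series", "measured", "known", "first", "only" and "open" are said of these compounds alone.

In a functional assay on UACC-62 cells (Homo sapiens) for cytotoxicity, read by sulforhodamine B assay (on this read-out higher numbers stand for lower toxicity in this test and lower numbers for higher toxicity in this test), compound 1 `CC1=CC[C@@H]([C@@](C)(O)CCCC(C)(C)NC(=S)N/N=C\c2ccc(N(C)C)cc2)CC1` gives > 100000 nM, which is a limit. Compound 2 `CC1=CC[C@@H]([C@@](C)(O)CCCC(C)(C)NC(=S)N/N=C\c2ccccc2Cl)CC1` gives > 100000 nM, which is also a limit, so it stands at the limit of > 100000 nM in this assay, at which 2 of the 2 values shown sit. Compound 3 `CC1=CC[C@@H]([C@@](C)(O)CCCC(C)(C)NC(=S)N/N=C\c2ccc(Cl)cc2)CC1` carries 4-chlorophenyl in place of 2-chlorophenyl on a carbon with a double bond to nitrogen. Among the measured compounds shown here, the only measured step is a step that the two limits leave unreadable from compound 1 to compound 2, so it offers no size to carry over, and no step beyond the scatter is expected in this assay, in either direction. The estimated change is a number no higher from compound 2 to compound 3 (the limit leaves the size open). Compound 3 is expected at about 100000 nM, within an estimated range of 40000 nM to 200000 nM.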

Compound 3, concentration lethal to 50% of the cells: 40600 nM
Compound 3: the middle estimate sits 2.5-fold (0.39 log units) above what was measured, and the stated range covers the measured number.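

In this assay, 4-chlorophenyl in place of 2-chlorophenyl gives an at least 2.4-fold lower number from compound 2 to compound 3 (0.39 log units; beyond the scatter), so with the same atoms joined differently, this place on the carbon with a double bond to nitrogen does respond to the change. Chloro in place of dimethylamino on an aromatic carbon gives an at least 2.4-fold lower number from compound 1 to compound 3 (0.39 log units; beyond the scatter). The earlier step between two limits could not be read, and compound 3 is the first to give a readable number: the limit of > 100000 nM in this assay, at which 2 of the 3 values shown sit.

Going by these compounds, both new steps start from a limit, so their true size stays open. Also open, on these data alone, is what 4-fluorophenyl or 4-methoxyphenyl would give at this place.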